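Chain extension on the ester of the shared core and cytotoxicity

The compounds below may be only part of what the source reports. "The series", "measured", "known", "first", "only" and "open" are said of these compounds alone.

Compound 1 `CCCCOC(=O)CCC(=O)N1CCN(CCCOc2cc3c(Nc4ccc(F)c(Cl)c4)ncnc3cc2OC)CC1` gives 79.1% in a functional assay on A549 cells (Homo sapiens) for cytotoxicity, read by MTT assay, with a stated time of 24 h, tested at 40 uM; a higher number here means a weaker effect of the compound at the concentration tested, a lower number a stronger effect. Compound 2 `CCCCCOC(=O)CCC(=O)N1CCN(CCCOc2cc3c(Nc4ccc(F)c(Cl)c4)ncnc3cc2OC)CC1` gives 63.6%, and compound 3 `CCCCCCCCCCCOC(=O)CCC(=O)N1CCN(CCCOc2cc3c(Nc4ccc(F)c(Cl)c4)ncnc3cc2OC)CC1` gives 12%, the lowest of the three numbers. The steps run one way: a number 15.5 percentage points lower from compound 1 to compound 2 (beyond the scatter), a number 67.1 percentage points lower from compound 1 to compound 3 (beyond the scatter) and a number 51.6 percentage points lower from compound 2 to compound 3 (beyond the scatter), each longer chain giving a lower number. Compound 4 `CCCCCCCCCCCCCCCCCCCOC(=O)CCC(=O)N1CCN(CCCOc2cc3c(Nc4ccc(F)c(Cl)c4)ncnc3cc2OC)CC1` carries the change (octyl in place of hydrogen on a saturated chain carbon, ten or more bonds along the chain from an oxygen next to a carbonyl group). The same kind of step as before, so a further fall is expected, but compound 3 already leaves little room beneath it. For compound 4 the expected step is a number 5 percentage points lower from compound 3 to compound 4 (within the scatter). Compound 4 is therefore estimated at 7%, between 0% and 28%.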

Compound 4, a percentage reported as activity, at one concentration (the size of the read-out at that concentration, not a potency): 92.3%
Estimate against measurement, compound 4: 85.3 percentage points below; measured number above the stated range.
By their numbers in this assay, from the lowest: compound 3; then compound 2; then compound 1; then compound 4.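

In this assay the extension by octyl at this position reverses the series, with a number 80.3 percentage points higher from compound 3 to compound 4 (beyond the scatter) and thus a weaker effect at the concentration tested. The fall in the number seen along compound 1, compound 2 and compound 3 therefore does not hold for every longer chain, and compound 4 goes against it. No data shown account for the reversal. Open, going by these compounds, is where the turn lies among chains between those of compound 3 and compound 4, such as a tetradecyl ester. Also open, on these data alone, is how a terminal carboxylic acid or amine on the chain would read.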